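The source may hold more compounds than are shown below. What is called first, only, known or untested is meant among the compounds shown, and "the series" means these compounds.

Compound 2 `COc1cc(-c2cccc3nc(-c4ccc(F)cc4)oc23)cc(OC)c1OC` gives 8700 nM in a functional assay on NCI-H460 cells (Homo sapiens) for antiproliferative activity, read by MTT assay, with a stated time of 48 h (a lower number here means a stronger inhibitor, a higher number a weaker inhibitor), the higher of the two plain numbers seen here. Compound 1 `COc1ccc(-c2nc3cccc(-c4cc(OC)c(OC)c(OC)c4)c3o2)cc1OC` reaches only the limit > 25000 nM in this assay. Compound 3 `COc1cc(-c2cccc3nc(-c4ccc5cc[nH]c5c4)oc23)cc(OC)c1OC` gives 24 nM. Compound 4 `COc1cc(-c2cccc3nc(-c4cccs4)oc23)cc(OC)c1OC` differs from compound 2 in one place: thiophen-2-yl in place of 4-fluorophenyl on an aromatic carbon. Two measured steps at this aromatic carbon bear on it: an at least 2.8-fold lower number from compound 1 to compound 2 (0.45 log units; beyond the scatter), and a 360-fold lower number from compound 2 to compound 3 (2.56 log units; beyond the scatter); both show that the group at this place can move the number greatly. Within the data shown here, no measured step exchanges 4-fluorophenyl for thiophen-2-yl, so the direction remains open. The step expected is a 1.5-fold lower number from compound 2 to compound 4 (0.16 log units; within the scatter), not beyond the scatter. Compound 4 is estimated at 6000 nM, with a range from 800 nM to 25000 nM.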

Compound 4, half-maximal inhibitory concentration: 1600 nM
Compound 4: the middle estimate sits 3.8-fold (0.57 log units) above what was measured, and the stated range covers the measured number.
By their numbers in this assay, from the lowest: compound 3; then compound 4; then compound 2. At a limit, above all of these: compound 1.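

A five-membered aromatic ring with one hetero atom is accepted at this carbon, and exchanging 4-fluorophenyl for thiophen-2-yl gives a 5.4-fold lower number from compound 2 to compound 4 (0.74 log units; beyond the scatter). Thiophen-2-yl still does not match 1H-indol-6-yl, the change giving a 67-fold higher number from compound 3 to compound 4 (1.82 log units; beyond the scatter). Against 3,4-dimethoxyphenyl the change gives an at least 15-fold lower number from compound 1 to compound 4 (1.19 log units; beyond the scatter), a bound only, since compound 1 stands at a limit: the limit of > 25000 nM in this assay, at which 1 of the 4 values shown sits. The compounds shown leave open whether the sulfur or the smaller ring matters here, which a furan-2-yl or a plain phenyl group at this carbon would help to separate.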